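The source may hold more compounds than are shown below. What is called first, only, known or untested is meant among the compounds shown, and "the series" means these compounds.

Measured in a functional assay on DU-145 cells (Homo sapiens) for antiproliferative activity, read by colorimetric assay; a higher number here means a weaker inhibitor, a lower number a stronger inhibitor:

Compound 1 `CN(C)CC/N=C1\C=C(O)c2cn(-c3ccccc3)nc2C1=O`: "not determined" (no result reported)
Compound 2 `CCc1nc2c(o1)C(O)=C/C(=N\CCN(C)C)C2=O`: 220 nM

Going by the values given here, compound 2, at 220 nM, holds the only number in this small set, so it cannot be ranked against anything. Compound 1 carries a phenyl group but has no result, and it offers no guide. Compound 3 `CN(C)CC/N=C1\C=C(O)c2oc(-c3ccccc3)nc2C1=O` awaits measurement in this assay. It differs from compound 2 by phenyl in place of ethyl on an aromatic carbon of the five-membered aromatic ring with 1 nitrogen and 1 oxygen. Among the compounds with values here, no measured step shows what such an exchange does here, so the only anchor is compound 2 at 220 nM. The expected change is small, leaning slightly towards a stronger inhibitor, and is not expected to clear the usual scatter. The estimated change is a 1.5-fold lower number from compound 2 to compound 3 (0.17 log units; within the scatter). The estimate for compound 3 is 150 nM, with an expected range from 40 nM to 600 nM.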

Compound 3, half-maximal inhibitory concentration: 210 nM
The estimate for compound 3 lay 1.4-fold (0.15 log units) below the measured number; the measured number falls inside the stated range.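

In this assay, phenyl in place of ethyl on an aromatic carbon gives a 1.0-fold lower number from compound 2 to compound 3 (0.02 log units; within the scatter) and stays within the scatter. Going by these compounds alone, this is the first reading at this position, next to the ring nitrogen and next to the ring oxygen, and it shows that a group of 6 heavy atoms with a six-membered aromatic ring reads the same as ethyl, with 2 heavy atoms and no ring. No supporting measurement bears on why the two groups read alike. The compounds shown leave open whether a polar group at this position, such as an amine or a carboxylic acid, would move the number beyond the scatter. They also leave open how a longer alkyl chain or a phenyl ring bearing a methoxy or chloro group would read here.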